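The source may hold more compounds than are shown below. What is called first, only, known or untested is meant among the compounds shown, and "the series" means these compounds.

Compound 3 `CN(C(=O)NC(=O)c1ccccc1F)c1nc(C(F)(F)F)c(C(=O)N/N=C/c2ccccc2C(F)(F)F)s1` carries a 2-fluorophenyl on the carbonyl carbon of its acyl urea. In a functional assay on MCF7 cells (Homo sapiens) for inhibition, read by MTT assay, with a stated time of 72 h (a higher number here means a weaker inhibitor, a lower number a stronger inhibitor), compound 3 gives 12.2 ug/mL, the highest of the two numbers available. Its nearest neighbour is compound 1 `CN(C(=O)NC(=O)c1ccc(F)c(F)c1)c1nc(C(F)(F)F)c(C(=O)N/N=C/c2ccccc2C(F)(F)F)s1`, which in this assay gives 8.21 ug/mL; the step of a 1.5-fold higher number from compound 1 to compound 3 (0.17 log units; within the scatter) lies within the scatter, so changing the fluorine pattern on that phenyl made no real difference. Compound 2 `CN(C(=O)NC(=O)c1ccc(C(F)(F)F)cc1)c1nc(C(F)(F)F)c(C(=O)N/N=C/c2ccc(C(F)(F)F)cc2)s1` is a different case: in this assay it shows only a limit, > 100 ug/mL, which is the edge of what the assay reports (the limit of > 100 ug/mL in this assay, at which 1 of the 3 values shown sits). Compound 4 `CN(C(=O)NC(=O)c1ccc(C(F)(F)F)cc1)c1nc(C(F)(F)F)c(C(=O)N/N=C/c2ccccc2C(F)(F)F)s1` has not yet been measured. It differs from compound 3 in that (4-(trifluoromethyl)phenyl in place of 2-fluorophenyl on a carbonyl carbon). Within the data shown here, compound 2 also carries a 4-(trifluoromethyl)phenyl on a carbonyl carbon, yet it is not a single-change neighbour of compound 4, so its limit sets no firm step. Compound 4 is expected to give an estimated 30 ug/mL in this assay, between 8 ug/mL and 100 ug/mL. That expected step, a 2.5-fold higher number from compound 3 to compound 4 (0.39 log units; beyond the scatter), points toward a weaker inhibitor, though it rests on thin ground and a limit cannot be ruled out.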

Compound 4, half-maximal inhibitory concentration: 2.21 ug/mL
For compound 4 the middle estimate is 14-fold (1.13 log units) above the measured one; measured number outside the range, below it.
By their numbers in this assay, from the lowest: compound 4; then compounds 1 and 3 (each within the scatter of the next). At a limit, above all of these: compound 2.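

Changing the group on the carbonyl carbon does matter in this series: with the 2-(trifluoromethyl)phenyl held in place at the other end, a 5.5-fold lower number from compound 3 to compound 4 (0.74 log units; beyond the scatter) and a 3.7-fold lower number from compound 1 to compound 4 (0.57 log units; beyond the scatter), whereas the earlier change between two fluorophenyl groups stayed within the scatter. The 4-(trifluoromethyl)phenyl on the carbonyl carbon does not decide the outcome alone, as the other end also counts: an at least 45-fold lower number from compound 2 to compound 4 (1.65 log units; beyond the scatter), with 2-(trifluoromethyl)phenyl in place of 4-(trifluoromethyl)phenyl on the carbon with a double bond to nitrogen. The size of that step is only a bound, as compound 2 stands at a limit and not at a number: the limit of > 100 ug/mL in this assay, at which 1 of the 4 values shown sits.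

The compounds shown leave open whether the gain follows the trifluoromethyl group or its place on the ring, which a 2-(trifluoromethyl)phenyl on the same carbonyl carbon could help separate. From the compounds shown here alone, how a 4-chlorophenyl or a 4-methoxyphenyl would behave there also remains open.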